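Cytotoxicity notes on the ring swap at the chain carbon

The compounds below may be only part of what the source reports. "The series", "measured", "known", "first", "only" and "open" are said of these compounds alone.

In an ADME assay on Huh-7 cells (Homo sapiens) for cytotoxicity (on this read-out lower numbers stand for stronger inhibition of growth and higher numbers for weaker inhibition of growth), compound 3 `COc1cc2c(=O)c(C(=O)c3ccc(C)cc3)cn(Cc3ccc(Cl)cc3)c2cc1OC` gives 15500 nM, the lowest of the two numbers shown. Compound 1 `COc1cc2c(=O)c(C(=O)c3ccc(C)cc3)cn(CC3CCCCC3)c2cc1OC` gives 22000 nM in this assay, and the step of a 1.4-fold lower number from compound 1 to compound 3 (0.15 log units; within the scatter) lies within the scatter. In this assay compound 2 `COc1cc2c(=O)c(C(=O)c3ccc(C)cc3)cn(Cc3ccc(C(F)(F)F)cc3F)c2cc1OC` gives > 25000 nM, which is a limit and not a number; it sits at the limit of > 25000 nM in this assay, at which 1 of the 3 values shown sits. The steps of an at least 1.1-fold higher number from compound 1 to compound 2 (0.05 log units; that floor lies within the scatter) and an at least 1.6-fold lower number from compound 2 to compound 3 (0.20 log units; that floor lies within the scatter) are floors, also within the scatter. Compound 4 `COc1cc2c(=O)c(C(=O)c3ccc(C)cc3)cn(CC3CC3)c2cc1OC` carries the change (cyclopropyl in place of 4-chlorophenyl on a saturated chain carbon bound to an aromatic nitrogen). Within the data shown here, the only precedent, a saturated ring against an aryl ring, is a 1.4-fold lower number from compound 1 to compound 3 (0.15 log units; within the scatter), so no step beyond the scatter is expected in this assay. Compound 4 is estimated at 20000 nM, range 10000 nM to 40000 nM. The expected step is a 1.3-fold higher number from compound 3 to compound 4 (0.11 log units; within the scatter).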

Compound 4, concentration for 50% growth inhibition: "not active" (no number reported)
For compound 4 the study gives words and no number; there is nothing to compare the estimate with.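

Among these compounds, compound 4 is reported in words only, as "not active", so no step from compound 3 or any other compound can be read in this assay. Going by these compounds, how cyclopropyl compares numerically with 4-chlorophenyl at this place stays open.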